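The source may report more compounds than this note shows. Statements on the series, on what has been measured and on what is new or still open speak of the compounds shown alone.

Measured in a functional assay on A2780 cells (Homo sapiens) for antiproliferative activity, read by MTT assay, with a stated time of 48 h; a lower number here means a stronger inhibitor, a higher number a weaker inhibitor:
Compound 1 `C=C(c1cc(OC)c(OC)c(OC)c1)c1ccc(OC)cc1NC(=O)CN`: 30 nM
Compound 2 `C=C(c1cc(OC)c(OC)c(OC)c1)c1ccc(OC)cc1NC(=O)CN(C)C`: 240 nM

Compound 2 has the higher number of the two, so it is the weaker inhibitor. Compound 3 `C=C(c1cc(OC)c(OC)c(OC)c1)c1ccc(OC)c(O)c1NC(=O)CN(C)C` differs from it by hydroxy in place of hydrogen on an aromatic carbon. For the measured compounds named here, the only measured step, an 8.0-fold higher number from compound 1 to compound 2 (0.90 log units; beyond the scatter), changes the amine end of the chain, not an aromatic carbon. It therefore bears only indirectly, showing that one small change can matter here. Going by the values given here, no measured step shows a direction for adding hydroxy, so the expected change is small and uncertain: a 1.2-fold lower number from compound 2 to compound 3 (0.08 log units; within the scatter). The estimated value for compound 3 is 200 nM, with an expected range of 50 nM to 800 nM.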

Compound 3, half-maximal inhibitory concentration: 90 nM
For compound 3 the middle estimate is 2.2-fold (0.35 log units) above the measured one; low and high end bracket the measured number.
By their numbers in this assay, from the lowest: compound 1; then compound 3; then compound 2.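

Placing hydroxy on this aromatic carbon, ortho to the (((dimethylamino)methyl)carbonyl)amino group and ortho to a methoxy group, gives a 2.7-fold lower number from compound 2 to compound 3 (0.43 log units; beyond the scatter) in this assay. So this carbon of the ring, and not only the amine end of the chain, can shift the number by more than the usual scatter. Nothing measured here explains why the number moves in this direction.

Still open, on these data alone, is whether an amine or a fluorine on the same carbon would act like hydroxy. As far as these compounds go, it is also open whether hydroxy would produce a similar step on compound 1, which carries the unsubstituted amino group.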